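The source may report more compounds than this note shows. Statements on the series, on what has been measured and on what is new or still open speak of the compounds shown alone.

Measured compounds:
- compound 1 `CC(c1ccc(-c2ccccc2)c(F)c1)c1nnc2n1N=C(c1ccc(OC(F)(F)F)cc1)CS2`, giving 4800 nM in a functional assay on MCF7 cells (Homo sapiens) for inhibition, read by sulforhodamine B assay, with a stated time of 72 h; on this read-out lower numbers stand for stronger inhibition and higher numbers for weaker inhibition
- compound 2 `COc1ccc2cc(C(C)c3nnc4n3N=C(c3ccc(Br)cc3)CS4)ccc2c1`, giving 11500 nM in this assay

Of these two numbers, compound 1 holds the lower one; compound 2 stands clearly above it, and the gap between them is beyond the scatter. Among the compounds with values here, the two compounds differ in more than one place, so their values show only that compound 1 is the stronger inhibitor of the pair.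

Compound 3 `CC(c1ccc(-c2ccccc2)c(F)c1)c1nnc2n1N=C(c1ccc(Br)cc1)CS2` is not yet measured. It differs from compound 1 in one place: bromo in place of trifluoromethoxy on an aromatic carbon, the change sitting para to a large group on the shared core. Within the data shown here, no step between measured compounds isolates this exchange. The expectation is a small step from compound 1 to compound 3, a 1.4-fold higher number from compound 1 to compound 3 (0.13 log units; within the scatter), toward a slightly weaker inhibition in this assay, though within or near the scatter. Compound 3 is thus estimated at 6500 nM, between 2500 nM and 16000 nM.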

Compound 3, half-maximal inhibitory concentration: 7400 nM
Beside the measured number, compound 3's estimate is 1.1-fold (0.06 log units) below it; the measured number falls inside the stated range.
By their numbers in this assay, from the lowest: compounds 1, 3 and 2 (each within the scatter of the next, the first and the last beyond it).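

Within the data shown here, the step of a 1.5-fold higher number from compound 1 to compound 3 (0.19 log units; within the scatter) in this assay is the first in this set to isolate a single place, replacing 4-(trifluoromethoxy)phenyl with 4-bromophenyl on an otherwise unchanged compound. It shows that these two groups cannot be told apart at this position, even though bromo has one heavy atom and no hydrogen-bond acceptor, while trifluoromethoxy has five heavy atoms and one acceptor. No accompanying measurement offers an explanation for this result.

The compounds shown leave open whether this position accepts groups of a different kind, such as an amine or a carboxylic acid. They also leave open whether trifluoromethoxy in place of bromo on compound 2 would give a similarly small step.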